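A few compounds are considered here, and "the series" means these few. Any claim that something is new, unique, unknown or untested is made for them only; others in the source may bear on it.

Measured so far in a functional assay on A-431 cells (Homo sapiens) for cytotoxicity; on this read-out lower numbers stand for an effect already at smaller amounts and higher numbers for an effect only at larger amounts of compound
compound 1 `COC1=C(C)C(=O)/C(=C(O)/C=C/c2ccc(Br)cc2)C(=O)C1(C)C` gives 9 ug/mL
compound 2 `COC1=C(C)C(=O)/C(=C(O)/C=C/c2ccccc2OC)C(=O)C1(C)C` gives 6.6 ug/mL
compound 3 `COC1=C(C)C(=O)/C(=C(O)/C=C/c2ccc(O)cc2)C(=O)C1(C)C` gives 14.9 ug/mL

Compound 3 lies within the scatter of compound 1 and has a higher number than compound 2 (a 2.3-fold higher number from compound 2 to compound 3 (0.35 log units; beyond the scatter)). Compound 4 `COC1=C(C)C(=O)/C(=C(O)/C=C/c2ccc(F)cc2)C(=O)C1(C)C` has not yet been measured. It differs from compound 3 by fluoro in place of hydroxy on an aromatic carbon. The closest evidence is the exchange of bromo for hydroxy (a 1.7-fold higher number from compound 1 to compound 3 (0.22 log units; within the scatter)), which stayed within the scatter. Going by the values given here, no fluoro compound has been measured, so a small move back towards compound 1 is expected, not a clear change. The expected step is small (a 1.5-fold lower number from compound 3 to compound 4 (0.17 log units; within the scatter)). Compound 4 is expected at 10 ug/mL, with an estimated range from 5 ug/mL to 20 ug/mL.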

Compound 4, concentration for half-maximal effect: 4.1 ug/mL
Compound 4: the middle estimate sits 2.4-fold (0.39 log units) above what was measured; measured number outside the range, below it.
By their numbers in this assay, from the lowest: compounds 4, 2, 1 and 3 (each within the scatter of the next, the first and the last beyond it).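

In this assay the aromatic carbon para to a large group proves sensitive to its substituent: fluoro in place of hydroxy gives a step beyond the scatter (a 3.6-fold lower number from compound 3 to compound 4 (0.56 log units; beyond the scatter)), which the earlier bromo and hydroxy pair did not show. Fluoro also separates from bromo at this carbon (a 2.2-fold lower number from compound 1 to compound 4 (0.34 log units; beyond the scatter)), whereas 4-fluorophenyl in place of 2-methoxyphenyl stays a small step (a 1.6-fold lower number from compound 2 to compound 4 (0.21 log units; within the scatter)). Nothing measured here accounts for these steps. On these data alone, whether chloro, an amine or a carboxylic acid at this carbon would lie nearer fluoro or hydroxy remains open.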